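Sulfonyl substituent change on a chlorophenoxyacetic acid series

The source may hold more compounds than are shown below. What is called first, only, known or untested is meant among the compounds shown, and "the series" means these compounds.

Three compounds sharing one core were measured in an assay on CHO cells for displacement of a labelled ligand from prostaglandin D2 receptor 2 (Homo sapiens), read by scintillation counting; a higher number here means a weaker inhibitor, a lower number a stronger inhibitor:

Compound 1, `Cc1ccc(S(=O)(=O)N(C)C(C)C)cc1C#Cc1cc(Cl)ccc1OCC(=O)O`: compound 1 gives 3.8 nM
Compound 2, `Cc1ccc(S(=O)(=O)N2CCOCC2)cc1C#Cc1cc(Cl)ccc1OCC(=O)O`: compound 2 gives 3.6 nM
Compound 3, `Cc1ccc(S(C)(=O)=O)cc1C#Cc1cc(Cl)ccc1OCC(=O)O`: compound 3 gives 5 nM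

Compound 3 has the highest of the three numbers, but its gap to the others is small: a 1.3-fold higher number from compound 1 to compound 3 (0.12 log units; within the scatter) and a 1.4-fold higher number from compound 2 to compound 3 (0.14 log units; within the scatter) both stay within the scatter, so no order among the three can be claimed.

Compound 4, `Cc1ccc(S(=O)(=O)N(C)CCN(C)C)cc1C#Cc1cc(Cl)ccc1OCC(=O)O`, has not yet been measured. Its difference from compound 3 is (2-(dimethylamino)ethyl)(methyl)amino in place of methyl on a sulfonyl sulfur. The two steps that bear on this are those in which the same methyl on the sulfonyl sulfur was exchanged for an amino substituent: a 1.3-fold higher number from compound 1 to compound 3 (0.12 log units; within the scatter) and a 1.4-fold higher number from compound 2 to compound 3 (0.14 log units; within the scatter). Both changes left the number essentially unchanged. A third amino substituent at that position is therefore expected to give a step of about a 1.3-fold lower number from compound 3 to compound 4 (0.10 log units; within the scatter), no direction beyond the scatter. Compound 4 is estimated at 4 nM in this assay, with a likely range from 1.5 nM to 12 nM.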

Compound 4, inhibition constant: 369 nM
Compound 4: middle estimate off by 92-fold (1.96 log units), on the low side; measured number outside the range, above it.
By their numbers in this assay, from the lowest: compounds 2, 1 and 3 (each within the scatter of the next); then compound 4.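

In this assay the substituent on the sulfonyl sulfur turns out not to be freely exchangeable, as the three earlier compounds had suggested: (2-(dimethylamino)ethyl)(methyl)amino in place of methyl gives a 74-fold higher number from compound 3 to compound 4 (1.87 log units; beyond the scatter) and in place of morpholin-4-yl gives a 100-fold higher number from compound 2 to compound 4 (2.01 log units; beyond the scatter) in the same assay. The closest comparison is with compound 1, which also carries a methyl-substituted sulfonamide nitrogen, and 2-(dimethylamino)ethyl in place of isopropyl on that nitrogen gives a 97-fold higher number from compound 1 to compound 4 (1.99 log units; beyond the scatter) with nothing else altered. An amino substituent at this position is therefore compatible with a low number, as compound 1 and compound 2 show, and the large step goes with this particular chain; nothing available bears on why the step is so large.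

The compounds shown leave open whether the step follows the terminal dimethylamino group or the ethyl chain that carries it, a question that a 2-methoxyethyl group on the same nitrogen would address. They also leave open how a longer chain ending in the same amine, or a chain ending in a carboxylic acid, would read in this position.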